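A few compounds are considered here, and "the series" means these few. Any claim that something is new, unique, unknown or untested is made for them only; others in the source may bear on it.

Compound 1, with the structure `Sc1nncn1Cc1ccccc1`, is a small molecule tested in an assay on isolated protein for inhibition of Dopamine beta-hydroxylase (Bos taurus); on this read-out higher numbers stand for weaker inhibition and lower numbers for stronger inhibition. In this assay compound 1 gives 24000 nM. Compound 2, with the structure `Fc1cccc(Cn2cnnc2S)c1`, carries one change on the shared core: fluoro in place of hydrogen on an aromatic carbon. The effect of this change is a 13-fold lower number from compound 1 to compound 2 (1.10 log units; beyond the scatter), so that compound 2 gives 1900 nM in this assay.

Compound 3, with the structure `Fc1cccc(Cn2ncnc2S)c1`, has a core that differs from that of compound 1, but the difference between the two cores is not broken down here. In this assay compound 3 gives 15000 nM, which sits close to the number for compound 1 and well apart from the number for compound 2.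

Compound 4, with the structure `Fc1cc(F)cc(Cn2ncnc2S)c1`, is the not yet measured compound. It differs from compound 3 by fluoro in place of hydrogen on an aromatic carbon. This is the same kind of change as that from compound 1 to compound 2, not the same change, since the place now lies meta to a fluoro group (1 heavy atom) as well as meta to a group of 7 heavy atoms. Because the earlier change gave a 13-fold lower number from compound 1 to compound 2 (1.10 log units; beyond the scatter), a step in the same direction is expected from compound 3 to compound 4 in this assay, although a somewhat smaller one, estimated as a 3.3-fold lower number from compound 3 to compound 4 (0.52 log units; beyond the scatter). On that basis the number expected for compound 4 in this assay is 4500 nM, most likely between 1500 nM and 13000 nM.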

Compound 4, half-maximal inhibitory concentration: 6200 nM
For compound 4 the middle estimate is 1.4-fold (0.14 log units) below the measured one; low and high end bracket the measured number.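

Replacing a hydrogen on an aromatic carbon with fluoro again lowers the number in this assay, with a 2.4-fold lower number from compound 3 to compound 4 (0.38 log units; beyond the scatter), so in these two pairs the direction of the change carries over from one core to the other. The size of the step does not carry over, and the gap between the two steps is larger than repeated measurements would explain: the same change on two cores in this assay, a 13-fold lower number (1.10 log units; beyond the scatter) from compound 1 to compound 2 and a 2.4-fold lower number (0.38 log units; beyond the scatter) from compound 3 to compound 4, 5.2-fold (0.72 log units) apart, beyond the scatter of two such steps These two pairs do not show why the steps differ, since the cores are not the only difference: in compound 4 the entering fluoro lies meta to a fluoro group already on the ring, so the effect of the core cannot be separated from the effect of that first fluoro, and two pairs are too few to support a general rule.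

The compounds shown leave open whether a second fluoro on the core of compound 2 would give a small step like the one seen in compound 4, which would point away from the core as the source of the gap. They also leave open whether a chlorine, a methoxy group or an amine at these ring places would lower the number as fluoro does, or would change it differently on each core.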